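Permeability notes: cyclopropyl to tert-butyl on the hydroxyacyl side chain

A few compounds are considered here, and "the series" means these few. Any claim that something is new, unique, unknown or untested is made for them only; others in the source may bear on it.

Three compounds of this series have been run in an ADME assay on Caco-2 cells (Homo sapiens) for permeability, read by LC-MS, in the apical to basolateral direction, with a stated time of 60 min, at pH 6.5; on this read-out higher numbers stand for higher permeability and lower numbers for lower permeability. Compound 1 `CC(C)(C)C[C@@H](O)C(=O)N1[C@@H]2C[C@@H]2C[C@H]1C(=O)NCc1cc(Cl)ccc1-n1cnnn1` gives 24 10^-6 cm/s. Compound 3 `O=C(NCc1cc(Cl)ccc1-n1cnnn1)[C@@H]1CC=NN1C(=O)[C@H](O)c1ccccc1` gives 7 10^-6 cm/s. Compound 2 `O=C(NCc1cc(Cl)ccc1-n1cnnn1)[C@@H]1C[C@@H]2C[C@@H]2N1C(=O)[C@H](O)CC1CC1` gives 3.6 10^-6 cm/s, the lowest of the three numbers; its gap to compound 3 lies within the scatter, while its gap to compound 1 lies beyond it. Within the data shown here, no pair of these measured compounds differs in a single place, so no clean step can be read from them.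

Compound 4 `CC(C)(C)C[C@@H](O)C(=O)N1[C@H](C(=O)NCc2cc(Cl)ccc2-n2cnnn2)C[C@@H]2C[C@@H]21` has not yet been measured in this assay. It differs from compound 2 in one place: tert-butyl in place of cyclopropyl on a saturated chain carbon, two bonds along the chain from a carbonyl carbon and an oxygen on a saturated carbon. Among the measured compounds shown here, the same side chain that enters here, neopentyl, is the one carried by compound 1, whose value is well above that of compound 2.

Expectation: the number for compound 4 is expected to move upward from compound 2 by a 3.3-fold higher number from compound 2 to compound 4 (0.52 log units; beyond the scatter), a step beyond the scatter, because compound 1 with the neopentyl chain gives 24 10^-6 cm/s while compound 2 gives 3.6 10^-6 cm/s. The two cores are not identical, so this is a rough guide only. Compound 4 is estimated at 12 10^-6 cm/s, with a range from 5 10^-6 cm/s to 28 10^-6 cm/s.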

Compound 4, apparent permeability: 25 10^-6 cm/s
For compound 4 the middle estimate is 2.1-fold (0.32 log units) below the measured one; low and high end bracket the measured number.
By their numbers in this assay, from the lowest: compounds 2 and 3 (each within the scatter of the next); then compounds 1 and 4 (each within the scatter of the next).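

Working notes on the side chain: in this assay the change from cyclopropyl to tert-butyl, on a saturated chain carbon, two bonds along the chain from a carbonyl carbon and an oxygen on a saturated carbon, can now be read as a single-place step, which the earlier compounds did not allow (a 6.9-fold higher number from compound 2 to compound 4 (0.84 log units; beyond the scatter)). That step lies beyond the usual scatter, so the identity of this group matters to the read-out on the core shared by compound 2 and compound 4. The neopentyl pair adds a second point, as its step lies within the scatter (a 1.0-fold higher number from compound 1 to compound 4 (0.02 log units; within the scatter)), and the two compounds show no separable change in this read-out despite one structural difference between them: the fact that compounds 1 and 4 differ only in the configuration as drawn.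

The compounds shown leave open whether an isopropyl group or a longer straight chain at this place would read with compound 2 or with compound 4, so a single step cannot say which feature of the exchanged groups carries the change. They also leave open whether the cyclopropylmethyl chain would tolerate the configuration change seen in the neopentyl pair.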